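From benzoyl to 4-chlorophenyl on a cytotoxic scaffold

The compounds below may be only part of what the source reports. "The series", "measured", "known", "first", "only" and "open" are said of these compounds alone.

Values in a functional assay on NALM-6 cells (Homo sapiens) for cytotoxicity, with a stated time of 72 h; on this read-out lower numbers stand for an effect already at smaller amounts and higher numbers for an effect only at larger amounts of compound:
Compound 1 `C=C[C@@](C)(/C=C/c1ccc(O)cc1)CCC1OC1(C)C`: > 43400 nM (a limit)
Compound 2 `C=C[C@@](C)(/C=C/c1ccc(O)cc1)CC/C=C(\C)CO`: > 43400 nM (a limit)
Compound 3 `C=C[C@@](C)(/C=C/c1ccc(O)c(/C=C/C(=O)c2ccccc2)c1)CCC=C(C)C`: 4470 nM

Compound 3 is the only one of the three with an actual number, 4470 nM. Compound 1 and compound 2 stand at the limit of > 43400 nM in this assay, at which 2 of the 3 values shown sit.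

Compound 4 `C=C[C@@](C)(/C=C/c1ccc(O)c(/C=C/c2ccc(Cl)cc2)c1)CCC=C(C)C` departs from compound 3 in a single exchange: 4-chlorophenyl in place of benzoyl on a double-bonded chain carbon bound to a double-bonded chain carbon. Thus 4-chlorophenyl takes the place of benzoyl on a double-bonded chain carbon bound to a double-bonded chain carbon.

Going by the values given here, the one measured step, a step that the two limits leave unreadable from compound 1 to compound 2, concerns a different part of the molecule and has no readable size, so it does not bear on this exchange. Among the compounds with values here, no measured step covers the loss of benzoyl. The expectation in this assay is therefore only tentative: a modest move toward higher numbers, with some chance that compound 4 reaches a limit.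

The expected step is a 1.6-fold higher number from compound 3 to compound 4 (0.19 log units; within the scatter). For compound 4 the estimated value is 7000 nM, within an expected range of 2000 nM to 25000 nM.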

Compound 4, half-maximal effective concentration: > 43400 nM
Compound 4 gave a limit, no number; the forecaster's own chance of this, stated with the estimate: 20%; middle value at least 6.2-fold (0.79 log units) away from the limit.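

Going by these compounds alone, the exchange of benzoyl for 4-chlorophenyl on a double-bonded chain carbon bound to a double-bonded chain carbon gives the first readable step in this assay, an at least 9.7-fold higher number from compound 3 to compound 4 (0.98 log units; beyond the scatter), so this position is not indifferent to the change. With benzoyl in place, compound 3 keeps a measurable value, and with 4-chlorophenyl that value is lost. As far as these compounds go, compound 4 gives > 43400 nM, which is a limit and not a number, and the true size of the step stays unknown, with compound 4 now at the same limit as compound 1 and compound 2: the limit of > 43400 nM in this assay, at which 3 of the 4 values shown sit.

The exchange takes away the carbonyl and brings in chlorine in one step, and the compounds shown do not tell these two parts apart. From the compounds shown here alone, how 4-chlorobenzoyl, a plain phenyl or an aminophenyl would read at this place remains open.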